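The compounds below may be only part of what the source reports. "The series", "measured", "known", "first", "only" and "open" are said of these compounds alone.

Compound 1 `CCCCCCCc1cn(C(c2ccccc2)c2cc3cc(Br)ccc3nc2OC)nn1` gives 0.17% in an ADME assay on HEK293 cells (Homo sapiens) for cytotoxicity, read by sulforhodamine B assay, with a stated time of 48 h, tested at 10 uM; a higher number here means more inhibition at the concentration tested (going by the name of the read-out), a lower number less inhibition.
Compound 2 `CCCCc1cn(C(c2ccccc2)c2cc3cc(Br)ccc3nc2OC)nn1` gives -3.47%.
Compound 3 `CCCCCCCCc1cn(C(c2ccccc2)c2cc3cc(Br)ccc3nc2OC)nn1` gives 14.6%.

Among these three numbers compound 1 stands second highest: its nearest neighbour is compound 2 (a number 3.6 percentage points lower from compound 1 to compound 2 (within the scatter)), its furthest is compound 3 (a number 14.4 percentage points higher from compound 1 to compound 3 (beyond the scatter)). Compound 4 `COc1nc2ccc(Br)cc2cc1C(c1ccccc1)n1cc(-c2ccc(OC(F)(F)F)cc2)nn1` differs from compound 1 in one place: 4-(trifluoromethoxy)phenyl in place of heptyl on an aromatic carbon. Every measured step only lengthens or shortens the chain; the two that go beyond the scatter, a number 14.4 percentage points higher from compound 1 to compound 3 (beyond the scatter) and a number 18.1 percentage points higher from compound 2 to compound 3 (beyond the scatter), both end at compound 3 with the longest chain and the highest number. None swaps the chain for a ring, so those steps bear on compound 4 only loosely. A modest rise is expected at most, a number 7.8 percentage points higher from compound 1 to compound 4 (within the scatter). Compound 4 is therefore expected to give about 8%, within the range -6% to 26%.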

Compound 4, a percentage reported as inhibition, at one concentration (the size of the read-out at that concentration, not a potency): 5.8%
Compound 4: the middle estimate sits 2.2 percentage points above what was measured; the range from low to high includes it.
By their numbers in this assay, from the lowest: compounds 2, 1, 4 and 3 (each within the scatter of the next, the first and the last beyond it).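

At an aromatic carbon of the five-membered ring, replacing a saturated chain with a 4-(trifluoromethoxy)phenyl ring leaves the number in this assay within the scatter of all three chain compounds, whether heptyl (a number 5.6 percentage points higher from compound 1 to compound 4 (within the scatter)), butyl (a number 9.3 percentage points higher from compound 2 to compound 4 (within the scatter)) or octyl (a number 8.8 percentage points lower from compound 3 to compound 4 (within the scatter)). The earlier compounds shown here showed only chain steps, so compound 4 adds the first ring at this position.

From the compounds shown here alone, whether a plain phenyl, an amine or a carboxylic acid at this carbon would stay in this range remains open. Nothing measured here offers an explanation for these numbers.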